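Chloro addition across two aryl ether series

This account rests on a few compounds, and the source may have more. Where it says the series, first, only, none or still open, it means among the compounds named here.

Measured so far:
compound 1 `C=C[C@@](C)(/C=C/c1ccc(OCc2cn(-c3ccccc3)nn2)cc1)CCC=C(C)C` gives 172000 nM in a toxicity assay on RAW264.7 cells (Mus musculus) for cytotoxicity, read by MTT assay, with a stated time of 24 h; a lower number here means a stronger inhibitor, a higher number a weaker inhibitor
compound 2 `C=C[C@@](C)(/C=C/c1ccc(OCc2cn(-c3ccc(Cl)cc3)nn2)cc1)CCC=C(C)C` gives 47600 nM in this assay
compound 3 `C=C[C@@](C)(/C=C/c1ccc(OC(=O)c2cc3ccccc3[nH]2)cc1)CCC=C(C)C` gives 108000 nM in this assay

Within the data shown here, the one counted step is a 3.6-fold lower number from compound 1 to compound 2 (0.56 log units; beyond the scatter), the change being (chloro in place of hydrogen on an aromatic carbon). Compound 4 `C=C[C@@](C)(/C=C/c1ccc(OC(=O)c2cc3cc(Cl)ccc3[nH]2)cc1)CCC=C(C)C` is not yet measured; it differs from compound 3 by chloro in place of hydrogen on an aromatic carbon. This is the same kind of change as from compound 1 to compound 2, not the same: in the first pair the place is para to a large group, in the second it sits on a fused system of two rings, meta and para to a fused ring. The difference between the two cores of compound 1 and compound 3 is not broken down here. Resting on the step from compound 1 to compound 2 in this assay, compound 4 is expected to step by a 2.4-fold lower number from compound 3 to compound 4 (0.38 log units; beyond the scatter). Compound 4 is estimated at 45000 nM, between 20000 nM and 110000 nM.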

Compound 4, half-maximal inhibitory concentration: 110000 nM
Beside the measured number, compound 4's estimate is 2.4-fold (0.39 log units) below it; the range from low to high includes it.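

In this assay, the change seen on the core of compound 1 does not carry over to the core of compound 3, where 1H-indol-2-yl to 5-chloro-1H-indol-2-yl gives a 1.0-fold higher number from compound 3 to compound 4 (0.01 log units; within the scatter). The two steps differ: the same change on two cores in this assay, a 3.6-fold lower number (0.56 log units; beyond the scatter) from compound 1 to compound 2 and a 1.0-fold higher number (0.01 log units; within the scatter) from compound 3 to compound 4, 3.7-fold (0.57 log units) apart, beyond the scatter of two such steps This shows that, in these two pairs, the step on one core does not predict the step on the other, but with one pair per core and the chloro at a different place in each, it does not separate the effect of the core from that of the place.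

Open, on these data alone, is whether bromo, methoxy or an amine in place of chloro would also differ between the two cores. Also open, as far as these compounds go, is whether chloro elsewhere on either core would follow either step.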